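Swapping Trifluoromethyl for Methyl on an Aromatic Carbon

The source may report more compounds than this note shows. Statements on the series, on what has been measured and on what is new or still open speak of the compounds shown alone.

Compound 1 `CCn1cc(C(=O)O)c(=O)c2cc(F)c(N3CCN(C(=N)NS(=O)(=O)c4ccc(C(F)(F)F)cc4)CC3)cc21`: 71 nM
Compound 2 `N=C(NS(=O)(=O)c1ccc(Cl)cc1)N1CCN(c2cc3c(cc2F)c(=O)c(C(=O)O)cn3C2CC2)CC1`: 71 nM

These two values come from a functional assay on A549 cells (Homo sapiens) for antiproliferative activity, read by MTT assay, with a stated time of 72 h; on this read-out lower numbers stand for stronger inhibition and higher numbers for weaker inhibition. For the measured compounds named here, compound 1 stands level with compound 2, the only other compound measured so far, and the gap between them is within the usual scatter of repeat measurements. Compound 3 `CCn1cc(C(=O)O)c(=O)c2cc(F)c(N3CCN(C(=N)NS(=O)(=O)c4ccc(C)cc4)CC3)cc21` has not yet been measured. It keeps everything in compound 1 except for one group: methyl in place of trifluoromethyl on an aromatic carbon, para to a large group (methyl in place of trifluoromethyl on an aromatic carbon).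

Going by the values given here, no pair of measured compounds differs in just one place, so no measured step can serve as a direct guide to this swap. The only clue is weak: compound 1 at 71 nM and compound 2 at 71 nM are level although their structures differ in more than one place. In this assay no step beyond the scatter is therefore expected, and any drift could go either way. The estimated change is a 1.3-fold higher number from compound 1 to compound 3 (0.10 log units; within the scatter). For compound 3 the expected value is 90 nM, with an estimated range of 30 nM to 270 nM.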

Compound 3, half-maximal inhibitory concentration: 71 nM
The estimate for compound 3 lay 1.3-fold (0.10 log units) above the measured number, and the stated range covers the measured number.
By their numbers in this assay, from the lowest: compounds 1, 2 and 3 (each within the scatter of the next).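

For the compounds shown here, this is the first pair that differs in one place only, so the swap can now be read directly: in this assay, going from 4-(trifluoromethyl)phenyl to 4-methylphenyl gives no change at the digits printed from compound 1 to compound 3 (within the scatter) on this read-out. At this aromatic carbon, para to a large group, trifluoromethyl with its 4 heavy atoms can therefore give way to methyl with its 1 heavy atom, and the antiproliferative read-out on these cells holds steady, so the three fluorine atoms are not needed for the number seen here. No measurement offered here bears on why the two groups read alike, so the result stands as an observation without an explanation.

The compounds shown leave open whether this position would stay as undemanding with a group of another kind in the same place, such as a methoxy group, a nitrile or a longer alkyl chain. They also leave open whether the same swap would read alike on a different core or in a different cell line, as this is a single pair in a single assay.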